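The compounds below may be only part of what the source reports. "The series", "measured", "known", "first", "only" and "open" are said of these compounds alone.

Working notes on the series in a functional assay on HL60/MX2 cells (Homo sapiens) for antiproliferative activity, read by MTT assay, with a stated time of 48 h; a lower number here means a stronger inhibitor, a higher number a weaker inhibitor. Among the measured compounds shown here, compound 1 (`CN(C)CCn1c(N)c(-c2nc3ccccc3[nH]2)c2nc(C#N)c(C#N)nc21`) gives 3780 nM, the second highest of the three numbers so far, and its steps to both measured neighbours stay within the scatter. Compound 2 (`CCN(CC)CCn1c(N)c(-c2nc3ccccc3[nH]2)c2nc(C#N)c(C#N)nc21`) gives 7150 nM, and compound 3 (`CN(C)CCCn1c(N)c(-c2nc3ccccc3[nH]2)c2nc(C#N)c(C#N)nc21`) gives 2390 nM.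

Compound 4 (`CCN(CC)CCCn1c(N)c(-c2nc3ccccc3[nH]2)c2nc(C#N)c(C#N)nc21`) is still unmeasured. Relative to compound 1 the change is (diethylamino)methyl in place of dimethylamino on a saturated chain carbon, two bonds along the chain from an aromatic nitrogen. Cut one bond further out, this reads 2-(dimethylamino)ethyl to 3-(diethylamino)propyl.

Two measured steps each carry one part of this change. The diethylamino half appears as a 1.9-fold higher number from compound 1 to compound 2 (0.28 log units; within the scatter), and the added chain carbon appears as a 1.6-fold lower number from compound 1 to compound 3 (0.20 log units; within the scatter). The two point opposite ways, and neither is firm on its own. For the measured compounds named here, the only step beyond the scatter so far is a 3.0-fold lower number from compound 2 to compound 3 (0.48 log units; beyond the scatter), which combines both differences in a different pairing. Going by the values given here, no measured compound yet tests whether the two halves simply add.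

If they do add, they nearly cancel. The expected result is a 1.2-fold higher number from compound 1 to compound 4 (0.08 log units; within the scatter), so no step beyond the scatter is expected in this assay. For compound 4 the estimated value is 4500 nM, with an expected range of 2300 nM to 8800 nM.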

Compound 4, half-maximal inhibitory concentration: 1820 nM
Estimate against measurement, compound 4: 2.5-fold (0.39 log units) above; measured number below the stated range.
By their numbers in this assay, from the lowest: compounds 4, 3, 1 and 2 (each within the scatter of the next, the first and the last beyond it).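

In this assay, the clearest gain at this position comes with the longer chain on the diethylamino series: a 3.9-fold lower number from compound 2 to compound 4 (0.59 log units; beyond the scatter), for 2-(diethylamino)ethyl to 3-(diethylamino)propyl. Among the compounds shown here, the full change from the 2-(dimethylamino)ethyl group of compound 1 also clears the scatter, with a 2.1-fold lower number from compound 1 to compound 4 (0.32 log units; beyond the scatter), which no step from compound 1 had done before, so the two parts of the change do not cancel here. With the chain at 3-propyl, the diethylamino swap gives a 1.3-fold lower number from compound 3 to compound 4 (0.12 log units; within the scatter), and compound 3 and compound 4 cannot be told apart; the swap itself is not shown to depend on chain length, since its two readings stay close: the same change on two cores in this assay, a 1.9-fold higher number (0.28 log units; within the scatter) from compound 1 to compound 2 and a 1.3-fold lower number (0.12 log units; within the scatter) from compound 3 to compound 4, 2.5-fold (0.40 log units) apart, within the scatter of two such steps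

The compounds shown leave open whether a longer chain, such as a butyl chain carrying diethylamino, continues the gain seen with 3-(diethylamino)propyl. They also leave open how a cyclic amine such as pyrrolidine or morpholine would compare with diethylamino on the propyl chain.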